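Compound 3 to compound 4: a swap on the shared core

The source may report more compounds than this note shows. Statements on the series, on what has been measured and on what is new or still open speak of the compounds shown alone.

In a functional assay for inhibition, with Homo sapiens as the target (on this read-out higher numbers stand for weaker binding and lower numbers for tighter binding), compound 1 (`N#Cc1ccc(C2OCC(C/C=C\CCC(=O)O)C(c3cccnc3)O2)cc1`) gives 1290 nM, compound 2 (`O=C(O)CC/C=C\CC1COC(c2cccnc2)OC1c1cccnc1`) gives 759 nM and compound 3 (`O=C(O)CC/C=C\CC1COC(c2ccc3ccccc3c2)OC1c1cccnc1`) gives 1780 nM. Two steps fix the standing of compound 3: a 1.4-fold higher number from compound 1 to compound 3 (0.14 log units; within the scatter), and a 2.3-fold higher number from compound 2 to compound 3 (0.37 log units; beyond the scatter).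

Compound 4 (`CC(C)(Oc1ccccc1)C1OCC(C/C=C\CCC(=O)O)C(c2cccnc2)O1`) differs from compound 3 on a saturated ring carbon between two ring oxygen atoms: a group of 10 heavy atoms (9 carbon, 1 oxygen; one six-membered aromatic ring of carbon only) in place of a group of 10 heavy atoms (10 carbon; 2 six-membered aromatic rings of carbon only), on a saturated ring carbon. The three measured steps at this carbon bear on the change. Besides the two above, there is a 1.7-fold lower number from compound 1 to compound 2 (0.23 log units; within the scatter). Only one of the three passes the scatter, and that one is modest. For the measured compounds named here, no measured compound carries the entering group, so these steps give only a rough guide and the range stays wide.

No step beyond the scatter is expected in this assay. The expected step is a 1.4-fold lower number from compound 3 to compound 4 (0.14 log units; within the scatter). For compound 4 the estimated value is 1300 nM, with an expected range from 500 nM to 3200 nM.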

Compound 4, dissociation constant: 75.9 nM
The estimate for compound 4 lay 17-fold (1.23 log units) above the measured number; measured number outside the range, below it.
By their numbers in this assay, from the lowest: compound 4; then compounds 2, 1 and 3 (each within the scatter of the next, the first and the last beyond it).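

In this assay, the saturated ring carbon between two ring oxygen atoms tolerates far more change than the aromatic swaps among compounds 1, 2 and 3 revealed: the entering group, with one six-membered aromatic ring of carbon only and 1 hydrogen-bond acceptor, gives a 23-fold lower number from compound 3 to compound 4 (1.37 log units; beyond the scatter) and a 17-fold lower number from compound 1 to compound 4 (1.23 log units; beyond the scatter) and also a 10-fold lower number from compound 2 to compound 4 (1.00 log units; beyond the scatter) as the smallest of the three steps. Heavy-atom count alone does not set the number here, as naphthalen-2-yl and the entering group both have 10 heavy atoms, yet they mark the widest gap in the series. Nothing on hand accounts for this drop.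

The compounds shown leave open which part of the entering group carries the step, and whether an amine at this carbon would keep it. Also open, on these data alone, is whether the drop survives a longer chain in place of the 5-carboxypent-2-en-1-yl group.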